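Compound 1 to compound 4: acetyl for isobutyl

This account rests on a few compounds, and the source may have more. Where it says the series, first, only, none or still open, it means among the compounds named here.

Measured compounds:
- compound 1 `C=C1[C@H](OCC(C)C)[C@@H](OC(C)=O)[C@@H](OC(C)=O)C(C)(C)/C=C/[C@H](C)[C@H](OC(=O)c2ccccc2)[C@@]2(O)C[C@@](C)(OC(C)=O)[C@H](OC(C)=O)[C@@H]2[C@H]1OCC(C)C`: 4860 nM
- compound 2 `C=C1[C@H](OCC(C)C)[C@@H](OC(C)=O)[C@@H](OC(C)=O)C(C)(C)[C@@H]2O[C@H]2[C@H](C)[C@H](OC(=O)c2ccccc2)[C@@]2(O)C[C@@](C)(OC(C)=O)[C@H](OC(C)=O)[C@@H]2[C@H]1OCC(C)C`: 1120 nM
- compound 3 `CC(=O)O[C@@H]1[C@@H]2[C@@H](OCC(C)C)C3(CO3)[C@H](O)[C@@H](O)[C@@H](O)C(C)(C)/C=C/[C@H](C)[C@H](OC(=O)c3ccccc3)[C@@]2(O)C[C@@]1(C)O`: > 100000 nM (a limit, not a number)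

In a functional assay on NCI/ADR-RES cells (Homo sapiens) for positive allosteric modulation, read by MTT assay, with a stated time of 48 h, tested at 10 uM (on this read-out higher numbers stand for weaker inhibition and lower numbers for stronger inhibition), compound 1 gives 4860 nM, the higher of the two true numbers in the series. Compound 2 gives 1120 nM, a lower number by a margin beyond the usual scatter. Compound 3 stands at the limit of the assay, (the limit of > 100000 nM in this assay, at which 1 of the 3 values shown sits).

The next compound to be measured is compound 4 `C=C1[C@H](OC(C)=O)[C@@H](OC(C)=O)[C@@H](OC(C)=O)C(C)(C)/C=C/[C@H](C)[C@H](OC(=O)c2ccccc2)[C@@]2(O)C[C@@](C)(OC(C)=O)[C@H](OC(C)=O)[C@@H]2[C@H]1OCC(C)C`. Its difference from compound 1 is acetyl in place of isobutyl on an oxygen on a saturated carbon. The same change can also be read as isobutoxy to acetoxy.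

Within the data shown here, no measured pair isolates this change, so the expectation is loose. It starts from compound 1 at 4860 nM, and the range takes in the spread seen with compound 2 at 1120 nM. In this assay a small rise in the number is expected, not clearly beyond the scatter, and the expected move is a 1.2-fold higher number from compound 1 to compound 4 (0.09 log units; within the scatter). For compound 4 the estimated value is 6000 nM, with an expected range of 1800 nM to 20000 nM.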

Compound 4, half-maximal inhibitory concentration: 4810 nM
Beside the measured number, compound 4's estimate is 1.2-fold (0.10 log units) above it; the range from low to high includes it.
By their numbers in this assay, from the lowest: compound 2; then compounds 4 and 1 (each within the scatter of the next). At a limit, above all of these: compound 3.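

In this assay, among these compounds, the isobutoxy to acetoxy exchange gives a 1.0-fold lower number from compound 1 to compound 4 (0.00 log units; within the scatter) and so provides the first step that isolates one change at one place. At this oxygen on a saturated carbon, a group with 4 heavy atoms and 0 hydrogen-bond acceptors gives way to one with 3 heavy atoms and 1 hydrogen-bond acceptor, with no shift beyond the scatter on this read-out. The place therefore accepts both an ether and an ester in the core of compound 1 without a readable difference, though nothing shown here accounts for that result.

Among the compounds shown here, the single step covers only two groups at this place, so it leaves open whether a longer chain, such as an n-hexyl ether or a hexanoyl ester, or a group carrying an amine would also leave the number unchanged. Also open, going by these compounds, is whether the same exchange at the remaining isobutoxy group of compound 4 would read the same way in this assay, or whether that second place responds differently.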